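A few compounds are considered here, and "the series" means these few. Any claim that something is new, unique, unknown or untested is made for them only; others in the source may bear on it.

Measured in a functional assay on HT-29 cells (Homo sapiens) for antiproliferative activity, read by sulforhodamine B assay, with a stated time of 48 h; on this read-out lower numbers stand for stronger inhibition of growth and higher numbers for weaker inhibition of growth:
compound 1 `NS(=O)(=O)NCC1CCN(c2cc(-c3ccc(Cl)cc3)ncn2)CC1` gives 37700 nM.
compound 2 `NS(=O)(=O)NCC1CCN(c2cc(-c3cccc(Cl)c3)ncn2)CC1` gives 47500 nM.
compound 3 `COc1ccccc1-c1cc(N2CCC(CNS(N)(=O)=O)CC2)ncn1` gives no number, only a limit, > 100000 nM.

Compound 3 stands at the edge of what the numbers show: its entry in this assay is a limit and not a value (the limit of > 100000 nM in this assay, at which 1 of the 3 values shown sits). Both steps leading to it, an at least 2.6-fold higher number from compound 1 to compound 3 (0.42 log units; beyond the scatter) and an at least 2.1-fold higher number from compound 2 to compound 3 (0.32 log units; beyond the scatter), go beyond the scatter, so compound 3 is the weakest of the three measured. In contrast, a 1.3-fold higher number from compound 1 to compound 2 (0.10 log units; within the scatter) stays within the scatter, so the 4-chlorophenyl and 3-chlorophenyl analogues are not distinguished.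

Compound 4 `NS(=O)(=O)NCC1CCN(c2cc(-c3ccccc3Cl)ncn2)CC1` differs from compound 3 by chloro in place of methoxy on an aromatic carbon. Going by the values given here, no measured step covers this exact change. Among the compounds with values here, the steps that bear on it are the two into compound 3, which show the chlorophenyl analogues with lower numbers than the 2-methoxyphenyl one, and the step between compounds 1 and 2, which shows little dependence on which chlorophenyl is present. A modest downward step in this assay is therefore expected. For compound 4 the expected step is an at least 1.8-fold lower number from compound 3 to compound 4 (0.25 log units; that floor lies within the scatter). Because compound 3 is only known as a limit > 100000 nM, compound 4 may itself come back as a limit. Compound 4 is expected near 55000 nM, within 25000 nM to 150000 nM.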

Compound 4, concentration for 50% growth inhibition: > 100000 nM
Compound 4: only a limit was reported (the forecaster's own chance of this, stated with the estimate: 35%); middle value at least 1.8-fold (0.25 log units) away from the limit.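

In this assay, going by these compounds alone, the 2-chlorophenyl group is the first chlorophenyl separated from the others, with an at least 2.1-fold higher number from compound 2 to compound 4 (0.32 log units; beyond the scatter) and an at least 2.6-fold higher number from compound 1 to compound 4 (0.42 log units; beyond the scatter); the entry for compound 4 is a limit, so these steps give only a floor. The place of the chloro on the phenyl ring therefore matters in this series, which compounds 1 and 2 alone, with their 4-chlorophenyl and 3-chlorophenyl groups not distinguished, did not show. The step from compound 3 to compound 4 cannot be read, so methoxy and chloro at this place remain unseparated, because both entries are limits: the limit of > 100000 nM in this assay, at which 2 of the 4 values shown sit.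

Open, from the compounds shown here alone, is whether fluoro, methyl or plain hydrogen at this place would give a value short of the limit. Also open, going by these compounds, is whether a 3-methoxyphenyl or 4-methoxyphenyl group would match the chlorophenyl values of compounds 1 and 2.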